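Swapping a dimethylamino chain for an oxolane ring

The compounds below may be only part of what the source reports. "The series", "measured", "known", "first", "only" and "open" are said of these compounds alone.

Two compounds have been measured in an assay on membranes from brain for displacement of a labelled ligand from Sigma non-opioid intracellular receptor 1 (Cavia porcellus), read by scintillation counting, with a stated time of 120 min; a higher number here means a weaker inhibitor, a lower number a stronger inhibitor:

compound 1, `CCCCN1CCN(CCC(=O)Nc2nc3c(C)cccc3s2)CC1`, gives 204 nM
compound 2, `Cc1cccc2sc(NC(=O)CCN3CCN(CCCN(C)C)CC3)nc12`, gives 570 nM

For the measured compounds named here, compound 2 stands highest of the two numbers, its nearest neighbour being compound 1, and the one measured step, a 2.8-fold higher number from compound 1 to compound 2 (0.45 log units; beyond the scatter), lies beyond the scatter. Compound 3, `Cc1cccc2sc(NC(=O)CCN3CCN(CC4CCCO4)CC3)nc12`, has not yet been measured in this assay. It differs from compound 2 in a single place: oxolan-2-yl in place of 2-(dimethylamino)ethyl on a saturated chain carbon bound to an amine nitrogen in a ring. Going by the values given here, the only measured step concerns the introduction of the dimethylamino group onto the chain hanging from the ring amine, and that step raised the number modestly; the change to compound 3 removes that same group again and puts a five-membered ring carrying an oxygen in its place, for which no measured comparison exists. Since the group whose arrival raised the number now leaves, the number for compound 3 is expected to come back towards that of compound 1, giving an expected step of a 2.3-fold lower number from compound 2 to compound 3 (0.36 log units; beyond the scatter). The estimate for compound 3 is 250 nM, within a range from 80 nM to 800 nM.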

Compound 3, inhibition constant: 109 nM
Compound 3: the middle estimate sits 2.3-fold (0.36 log units) above what was measured; low and high end bracket the measured number.
By their numbers in this assay, from the lowest: compounds 3 and 1 (each within the scatter of the next); then compound 2.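

In this assay, oxolan-2-yl in place of 2-(dimethylamino)ethyl gives a 5.2-fold lower number from compound 2 to compound 3 (0.72 log units; beyond the scatter) even though the two groups match in heavy atoms, hydrogen-bond donors, hydrogen-bond acceptors and net charge, so those counts alone do not settle the number at this place, on a saturated chain carbon bound to an amine nitrogen in a ring. Oxolan-2-yl in place of propyl at the same place gives a 1.9-fold lower number from compound 1 to compound 3 (0.27 log units; within the scatter) and so leaves compound 1 and compound 3 indistinguishable in this assay, which shows that a ring containing oxygen is tolerated here as well as the plain carbon chain. No measurement shown here explains either result.

The compounds shown do not separate the contribution of the ring from that of its oxygen, a question that a cyclopentyl group in place of oxolan-2-yl could address. They also leave open whether the nitrogen of the dimethylamino group matters or the length of its chain, which a methoxy group on the same chain in place of dimethylamino could help to separate.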